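This account rests on a few compounds, and the source may have more. Where it says the series, first, only, none or still open, it means among the compounds named here.

Measured so far:
compound 1, `COc1cc(CC(O)c2ccc(-c3cccc(F)c3)cc2)c([N+](=O)[O-])cc1OC`: 7400 nM
compound 2, `COc1cc(CC(O)c2ccc(-c3ccccc3C#N)cc2)c([N+](=O)[O-])cc1OC`: 9300 nM

Within the data shown here, in an ADME assay on HeLa Rh cells (Homo sapiens) for cytotoxicity, read by microscopy (on this read-out lower numbers stand for higher toxicity in this test and higher numbers for lower toxicity in this test), compound 2 holds the higher of these two numbers, yet the only measured step, a 1.3-fold higher number from compound 1 to compound 2 (0.10 log units; within the scatter), lies within the scatter, so the two compounds cannot be told apart on this read-out.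

Compound 3, `COc1cc(CC(O)c2ccc(-c3ccccc3[N+](=O)[O-])cc2)c([N+](=O)[O-])cc1OC`, differs from compound 2 in one place: nitro in place of cyano on an aromatic carbon. Among the measured compounds shown here, the single measured step swapped one aromatic ring for another without moving the number beyond the scatter, and nothing measured here points to a larger effect for this swap. The step from compound 2 to compound 3 is therefore expected to be small: a 1.1-fold lower number from compound 2 to compound 3 (0.04 log units; within the scatter). Compound 3 is estimated at 8500 nM, with a range from 4000 nM to 18000 nM.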

Compound 3, half-maximal cytotoxic concentration: 9500 nM
The estimate for compound 3 lay 1.1-fold (0.05 log units) below the measured number; the range from low to high includes it.
By their numbers in this assay, from the lowest: compounds 1, 2 and 3 (each within the scatter of the next).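

Nitro in place of cyano, on an aromatic carbon ortho to a large group, gives a 1.0-fold higher number from compound 2 to compound 3 (0.01 log units; within the scatter) in this assay, so the two groups cannot be told apart here. The 2-nitrophenyl group in place of 3-fluorophenyl gives a 1.3-fold higher number from compound 1 to compound 3 (0.11 log units; within the scatter), so all three compounds read alike on this test. Nothing available here explains this result.

As far as these compounds go, whether an amine or a carboxylic acid at this place would move the number beyond the scatter remains open. So does the reading of an unsubstituted phenyl ring.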